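The source may hold more compounds than are shown below. What is called first, only, known or untested is meant among the compounds shown, and "the series" means these compounds.

Compound 1, `O=C(Nc1ccccc1)Nc1nc(NC2CC2)cc(Sc2c[nH]c3ccccc23)n1`, is one of three compounds built on a shared core, and in a functional assay on HepG2 cells (Homo sapiens) for inhibition, with a stated time of 72 h (on this read-out higher numbers stand for weaker inhibition and lower numbers for stronger inhibition), compound 1 gives 14300 nM. Compound 2, `O=C(Nc1ccccc1)Nc1nc(Sc2c[nH]c3ccccc23)cc(N2CCCC2)n1`, gives 11400 nM in this assay, and compound 3, `O=C(Nc1ccccc1)Nc1nc(Nc2ccc(Cl)cc2)cc(Sc2c[nH]c3ccccc23)n1`, gives 12600 nM. The step of a 1.3-fold lower number from compound 1 to compound 2 (0.10 log units; within the scatter) and the step of a 1.1-fold lower number from compound 1 to compound 3 (0.05 log units; within the scatter) both fall within the scatter, as does a 1.1-fold higher number from compound 2 to compound 3 (0.04 log units; within the scatter), so the three numbers cannot be told apart and compound 1 stands together with the other two.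

Compound 4, `Cc1cc(Cl)ccc1NC(=O)Nc1nc(NC2CC2)cc(Sc2c[nH]c3ccccc23)n1`, differs from compound 1 in a place the measured compounds leave untouched: 4-chloro-2-methylphenyl in place of phenyl on an amide-type nitrogen. Going by the values given here, all three measured steps alter a different group on the core and keep the phenyl on the amide-type nitrogen, so no measured step bears directly on the change from compound 1 to compound 4. Among the compounds with values here, the only guidance is that three changes made elsewhere on the same core produced no step beyond the scatter in this assay. The expectation for compound 4 is therefore a step of about a 1.2-fold lower number from compound 1 to compound 4 (0.08 log units; within the scatter), which is no change beyond the scatter, with the range widened to reflect the absence of a directly comparable step. Compound 4 is estimated at 12000 nM, with a range from 4500 nM to 32000 nM.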

Compound 4, half-maximal inhibitory concentration: 9740 nM
Compound 4: middle estimate off by 1.2-fold (0.09 log units), on the high side, and the stated range covers the measured number.
By their numbers in this assay, from the lowest: compounds 4, 2, 3 and 1 (each within the scatter of the next).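

This is the first change shown on the amide-type nitrogen, where the phenyl of compound 1 gives way to 4-chloro-2-methylphenyl, and in this assay it produces a 1.5-fold lower number from compound 1 to compound 4 (0.17 log units; within the scatter). The step lies within the scatter, so adding a chlorine and a methyl group together on this ring gives no change that can be told apart from repeat-to-repeat variation, and the earlier finding of no readable step on the other side of the shared core now has a counterpart at this position. No measurement here offers an explanation for this result.

The two new groups entered together, so this single step cannot show what the chlorine or the methyl group does alone, and one could hide a change that the other offsets. Also open, as far as these compounds go, is whether a carboxylic acid or an amine on this ring, or a cyclohexyl group in place of the phenyl, would move the number beyond the scatter in this assay.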